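The compounds below may be only part of what the source reports. "The series", "measured", "known", "first", "only" and "open" are said of these compounds alone.

Of the compounds shown here, two that share one core have been measured so far. Compound 1 `O=S(=O)(NCCNCc1cccc2ccccc12)c1cc(C(F)(F)F)cc(C(F)(F)F)c1` and compound 2 `O=S(=O)(NCCCNCc1ccccc1Cl)c1cc(C(F)(F)F)cc(C(F)(F)F)c1` were both tested in a functional assay on PANC-1 cells (Homo sapiens) for inhibition, read by MTT assay, with a stated time of 72 h; on this read-out lower numbers stand for stronger inhibition of growth and higher numbers for weaker inhibition of growth. In this assay compound 1 gives 24000 nM, and in this assay compound 2 gives 15000 nM. Compound 2 therefore holds the smaller of the two numbers, but its gap to compound 1 lies within the usual scatter of repeated measurements, so the two compounds cannot be told apart on these data.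

Compound 3 `CC(C)(C)c1ccc(CNCCCNS(=O)(=O)c2cc(C(F)(F)F)cc(C(F)(F)F)c2)cc1` remains to be measured in this assay. It differs from compound 2 in one place: 4-(tert-butyl)phenyl in place of 2-chlorophenyl on a saturated chain carbon bound to an amine nitrogen. For the measured compounds named here, no measured pair of compounds shows this change, so its effect cannot be read off the existing numbers. With only two measured points, both close together, a step of modest size is expected here, most likely toward a somewhat lower number or none beyond the scatter. The step that this expectation implies is a 1.5-fold lower number from compound 2 to compound 3 (0.18 log units; within the scatter). Compound 3 is accordingly estimated at 10000 nM, with a range from 4000 nM to 25000 nM.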

Compound 3, concentration for 50% growth inhibition: 2500 nM
Compound 3: middle estimate off by 4.0-fold (0.60 log units), on the high side; the whole stated range lies above it.
By their numbers in this assay, from the lowest: compound 3; then compounds 2 and 1 (each within the scatter of the next).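

Within this assay the exchange of 2-chlorophenyl for 4-(tert-butyl)phenyl on a saturated chain carbon bound to an amine nitrogen gives a 6.0-fold lower number from compound 2 to compound 3 (0.78 log units; beyond the scatter) and is the first step in this set that lies beyond the scatter. For the compounds shown here, the numbers of compounds 1 and 2 lie within the scatter of each other and those compounds differ in more than one place, so only this pair shows that the number responds to the group at this position. The exchange alters several things together, removing the chlorine, moving the ring substituent from the 2 to the 4 place as the group names show, and adding heavy atoms, so this one step cannot separate them.

Still open, from the compounds shown here alone, is whether 4-chlorophenyl, 2-(tert-butyl)phenyl or 4-methoxyphenyl would give a similar number at this position, and whether a longer chain in the core would alter the step. The data shown offer nothing that explains the size of this step.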